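Bromine on the benzyl arm of a nitro chalcone

The source may hold more compounds than are shown below. What is called first, only, known or untested is meant among the compounds shown, and "the series" means these compounds.

Measured compounds:
compound 1, `COc1ccc(C(=O)/C=C/c2ccc(OCc3cn(Cc4cccc(Br)c4)nn3)cc2)cc1`, in a functional assay on MCF7 cells (Homo sapiens) for inhibition, read by MTT assay, with a stated time of 48 h, tested at 10 uM (on this read-out lower numbers stand for less inhibition of growth and higher numbers for more inhibition of growth at the one concentration tested), compound 1 gives 45%
compound 2, `O=C(/C=C/c1ccc(OCc2cn(Cc3ccccc3)nn2)cc1)c1ccc([N+](=O)[O-])cc1`, in this assay compound 2 gives "not active" (no number reported)

Compound 2 stands apart from compound 1 in that it gives no number at all in this assay; it is simply reported as inactive, so no size can be put on where it lies. Compound 3, `O=C(/C=C/c1ccc(OCc2cn(Cc3cccc(Br)c3)nn2)cc1)c1ccc([N+](=O)[O-])cc1`, differs from compound 2 in one place: bromo in place of hydrogen on an aromatic carbon. For the measured compounds named here, no step between two measured compounds isolates this change. Compound 1 carries the same 3-bromobenzyl group and shows a moderate result in this assay, which is the only hint available; the ketone of compound 1 differs from that of compound 2 and compound 3, so the hint is weak. Compound 3 is expected to show modest inhibition, with a real chance that it too is reported as inactive. The estimate for compound 3 in this assay is 25%, with a range from 5% to 50%.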

Compound 3, percent growth inhibition at one concentration: 12%
For compound 3 the middle estimate is 13 percentage points above the measured one; the measured number falls inside the stated range.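

In this assay compound 3 gives 12% while compound 2, which has hydrogen in place of bromo, is reported only as not active, so the step between them cannot be read as a size. The firmer finding lies in the other substituent: with the 3-bromobenzyl group held constant, nitro in place of methoxy on an aromatic carbon gives a number 33 percentage points lower from compound 1 to compound 3 (beyond the scatter) and shows that this substituent strongly affects growth inhibition at the one concentration tested. Nothing presented here explains either result.

The compounds shown leave open how much bromo contributes when methoxy is present, since the plain benzyl partner of compound 1 is not among them. They also leave open how an amine or a carboxylic acid in place of the nitro would read.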